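Amide substituent exchange on a shared core, compound 4

The compounds below may be only part of what the source reports. "The series", "measured", "known", "first", "only" and "open" are said of these compounds alone.

Three measured compounds share one core and differ only in the group on the carbonyl carbon of the amide. Compound 1 `C=CC(=O)Nc1cccc(-c2nc3ccccc3s2)c1` carries the vinyl group; in an ADME assay on HepG2 cells (Homo sapiens) for inhibition, with a stated time of 72 h (on this read-out lower numbers stand for an effect already at smaller amounts and higher numbers for an effect only at larger amounts of compound), compound 1 gives a limit of > 25000 nM, not a number. Compound 2 `C/C=C/C(=O)Nc1cccc(-c2nc3ccccc3s2)c1` carries prop-1-en-1-yl in its place; in this assay compound 2 likewise gives only a limit of > 25000 nM. Compound 3 `C=C(C)C(=O)Nc1cccc(-c2nc3ccccc3s2)c1` carries 1-methylethenyl; in this assay compound 3 also returns only a limit of > 25000 nM. Compound 3 therefore stands at the same limit as the other two, and none of the three is ranked against another. The steps a step that the two limits leave unreadable from compound 1 to compound 2, a step that the two limits leave unreadable from compound 1 to compound 3 and a step that the two limits leave unreadable from compound 2 to compound 3 are all unreadable because of the limit of > 25000 nM in this assay, at which 3 of the 3 values shown sit.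

Compound 4 `O=C(Nc1cccc(-c2nc3ccccc3s2)c1)c1ccnc(Cl)c1` is the next member. Its change from compound 3 is 2-chloropyridin-4-yl in place of 1-methylethenyl on a carbonyl carbon. Among the compounds with values here, none of the measured steps is readable, so none bears on this change with a size; they show only that the three small alkenyl groups all sit at the limit. The expected step of a number no higher from compound 3 to compound 4 (the limit leaves the size open) in this assay is therefore set near zero, with the limit itself the most likely outcome. Compound 4 is estimated at 25000 nM in this assay, within 8000 nM to 60000 nM, pending the measurement.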

Compound 4, half-maximal effective concentration: > 25000 nM
Compound 4 gave a limit, no number; the forecaster's own chance of this, stated with the estimate: 75%; the middle value lies on the limit itself.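

No new step can be read from compound 4 to compound 1, compound 2 or compound 3 in this assay, because all four compounds share one limit: the limit of > 25000 nM in this assay, at which 4 of the 4 values shown sit.

The compounds shown leave open how far apart these four lie in this assay, and whether any group on the carbonyl carbon of the shared core gives a number rather than a limit.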